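The source may report more compounds than this note shows. Statements on the series, on what has been measured and on what is new or still open speak of the compounds shown alone.

Of the compounds shown here, three sharing one core have been measured in an assay for inhibition of kynurenine 3-monooxygenase (Homo sapiens), read by mass spectrometry, with a stated time of 1 h; on this read-out lower numbers stand for stronger inhibition and higher numbers for weaker inhibition. Compound 1 `C[C@@H](Oc1cc2oc(=O)n(CCC(=O)O)c2cc1Cl)c1ccc(F)cn1` gives 2.51 nM. Compound 2 `CC(C)Cc1cc2oc(=O)n(CCC(=O)O)c2cc1Cl` gives 12.6 nM. Among the compounds with values here, compound 3 `O=C(O)CCn1c(=O)oc2cc(OCc3ccccn3)c(Cl)cc21` gives 3.16 nM, which places compound 3 second highest of the three numbers: its gap to compound 1 lies within the scatter, while the only step that is counted here, a 4.0-fold lower number from compound 2 to compound 3 (0.60 log units; beyond the scatter), separates it from compound 2.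

Compound 4 `C[C@@H](Oc1cc2oc(=O)n(CCC(=O)O)c2cc1Cl)c1ncco1` has not yet been measured. It differs from compound 3 by a group of 7 heavy atoms (5 carbon, 1 nitrogen, 1 oxygen; one five-membered aromatic ring with 2 hetero atoms) in place of a group of 7 heavy atoms (6 carbon, 1 nitrogen; one six-membered aromatic ring with 1 hetero atom), on an oxygen on an aromatic ring. Within the data shown here, none of the measured steps covers this exchange of one aromatic ring for another on the ring oxygen; the single counted step concerns a different replacement, isobutyl for (pyridin-2-yl)methoxy, and is of modest size. The values of compound 1 and compound 3 show only that two variants of the six-membered ring on that oxygen both sit at low numbers in this assay. Among the measured compounds shown here, with no direct precedent, a small move towards a higher number is expected, but one that may well fall within the scatter.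

Compound 4 is expected to give about 8 nM, with a range from 2.5 nM to 25 nM. This estimate means an expected step of a 2.5-fold higher number from compound 3 to compound 4 (0.40 log units; beyond the scatter).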

Compound 4, half-maximal inhibitory concentration: 3.16 nM
Compound 4: middle estimate off by 2.5-fold (0.40 log units), on the high side; measured number inside the range.
By their numbers in this assay, from the lowest: compounds 1, 3 and 4 (each within the scatter of the next); then compound 2.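

The oxygen on the aromatic ring accepts more than a six-membered aromatic ring: in this assay, the five-membered aromatic ring with 2 hetero atoms, carrying a defined stereocentre, replaces (pyridin-2-yl)methyl with no change at the digits printed from compound 3 to compound 4 (within the scatter). The same holds on the saturated chain carbon, where 1,3-oxazol-2-yl in place of 5-fluoropyridin-2-yl gives a 1.3-fold higher number from compound 1 to compound 4 (0.10 log units; within the scatter), so neither the pyridine nitrogen arrangement nor the fluorine-bearing ring is required to stay at these low numbers in this series of compounds. Within the data shown here, the separation from the isobutyl compound also survives the change of ring, with a 4.0-fold lower number from compound 2 to compound 4 (0.60 log units; beyond the scatter), a step of the same size as the one the pyridine compound showed, so it now rests on two different aromatic rings joined through the oxygen.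

The compounds shown do not separate the effect of the ring from that of the defined stereocentre, and they leave open whether a phenyl ring, a 1,3-thiazol-2-yl ring or a saturated ring such as piperidine would read the same on that carbon. Nothing at hand bears on why the two ring types read alike.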